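This account rests on a few compounds, and the source may have more. Where it says the series, first, only, none or still open, it means among the compounds named here.

Measured compounds:
compound 1, `COc1ccc(-c2cn3cc(C4=CCN(C(=O)c5ccc(Cl)cc5)CC4)ccc3n2)cc1OC`, 8970 nM in a functional assay on A549 cells (Homo sapiens) for antiproliferative activity, read by MTT assay, with a stated time of 48 h; on this read-out higher numbers stand for weaker inhibition and lower numbers for stronger inhibition
compound 2, `COc1ccc(-c2cn3cc(C4=CCN(C(=O)c5ccccc5)CC4)ccc3n2)cc1OC`, 7700 nM in this assay
compound 3, `COc1ccc(-c2cn3cc(C4=CCN(S(=O)(=O)C5CCCC5)CC4)ccc3n2)cc1OC`, 6470 nM in this assay

Compound 1 carries the upper number of the three, yet the steps to compound 2 a 1.2-fold lower number from compound 1 to compound 2 (0.07 log units; within the scatter) and to compound 3 a 1.4-fold lower number from compound 1 to compound 3 (0.14 log units; within the scatter) both sit inside the scatter, so the three compounds cannot be separated on these numbers.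

Compound 4, `COc1ccc(-c2cn3cc(C4=CCN(C(=O)c5cccs5)CC4)ccc3n2)cc1OC`, is not yet measured in this assay. Its difference from compound 1 is thiophen-2-yl in place of 4-chlorophenyl on a carbonyl carbon.

Among the compounds with values here, three measured steps bear on it. Removal of chloro from the aromatic carbon, a 1.2-fold lower number from compound 1 to compound 2 (0.07 log units; within the scatter), changed nothing beyond the scatter. Exchange of the whole aroyl group for cyclopentylsulfonyl, a 1.4-fold lower number from compound 1 to compound 3 (0.14 log units; within the scatter) and a 1.2-fold lower number from compound 2 to compound 3 (0.08 log units; within the scatter), also stayed inside the scatter. Every change so far at the group on the amine nitrogen in the ring has left the read-out of this assay unmoved, and the move to thiophen-2-yl is of the same kind. No step beyond the scatter is therefore expected in this assay for compound 4, in either direction: the estimated step is a 1.1-fold lower number from compound 1 to compound 4 (0.05 log units; within the scatter).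

Compound 4 is estimated at 8000 nM in this assay, with a range from 4000 nM to 16000 nM.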

Compound 4, half-maximal inhibitory concentration: 5200 nM
Compound 4: the middle estimate sits 1.5-fold (0.19 log units) above what was measured; measured number inside the range.
By their numbers in this assay, from the lowest: compounds 4, 3, 2 and 1 (each within the scatter of the next).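

Working notes on the group on the carbonyl carbon: in this assay, this position accepts a five-membered aromatic ring with a sulfur atom as well as the six-membered carbon rings, with no step beyond the scatter, whether thiophen-2-yl replaces 4-chlorophenyl, a 1.7-fold lower number from compound 1 to compound 4 (0.24 log units; within the scatter), or phenyl, a 1.5-fold lower number from compound 2 to compound 4 (0.17 log units; within the scatter). Exchanging the cyclopentylsulfonyl group on the amine nitrogen in the ring for (thiophen-2-yl)carbonyl gives a 1.2-fold lower number from compound 3 to compound 4 (0.09 log units; within the scatter), so a change in ring size and ring atoms here, and the hydrogen-bond acceptor counted for the entering group, do not separate compound 4 from the other three compounds on these numbers. No measurement at hand offers an explanation for these numbers.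

Still open, going by these compounds, is whether any group at this position can move the read-out beyond the scatter, for instance a carboxylic acid, an amine or a longer chain in place of thiophen-2-yl. The shared core is the same in all four compounds, so these numbers say nothing about how changes to it would read in this assay.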